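Cyclohexyl for Hexyl on the Aryl Ether Chain

The source may hold more compounds than are shown below. What is called first, only, known or untested is meant among the compounds shown, and "the series" means these compounds.

Within the data shown here, in an assay on membranes from lung (Cavia porcellus) for binding affinity to cysteinyl leukotriene receptor (Homo sapiens) (on this read-out higher numbers stand for weaker inhibition and lower numbers for stronger inhibition), compound 2 `CCCCCCCCCOc1ccccc1C(SCCC(=O)O)SCCC(=O)O` gives 4090 nM, the higher of the two numbers measured so far. In this assay, among the measured compounds shown here, compound 1 `O=C(O)CCSC(SCCC(=O)O)c1ccccc1CCCCCCCCC1CCCCC1` gives 1960 nM; no step between these two has been worked out, so only their two values are known. Compound 3 `O=C(O)CCSC(SCCC(=O)O)c1ccccc1OCCCC1CCCCC1` differs from compound 2 by cyclohexyl in place of hexyl on a saturated chain carbon, three bonds along the chain from an oxygen on an aromatic ring. No measured step of this kind exists, and the author therefore expects only a small move toward lower numbers, close to the scatter, shown as a 1.4-fold lower number from compound 2 to compound 3 (0.13 log units; within the scatter). Compound 3 is estimated at 3000 nM, with a range from 1000 nM to 10000 nM.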

Compound 3, inhibition constant: 1010 nM
Beside the measured number, compound 3's estimate is 3.0-fold (0.47 log units) above it; the range from low to high includes it.
By their numbers in this assay, from the lowest: compounds 3 and 1 (each within the scatter of the next); then compound 2.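

Cyclohexyl in place of hexyl, on a saturated chain carbon, three bonds along the chain from an oxygen on an aromatic ring, gives a 4.0-fold lower number from compound 2 to compound 3 (0.61 log units; beyond the scatter) in this assay. Both groups count six carbons, so this position responds to a six-membered ring in place of an open chain without any added heavy atoms. No measurement here explains the step.

On these data alone, it remains open how a longer chain ending in cyclohexyl would read at this position. The same holds for a phenyl ring or an amine in place of the cyclohexyl.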